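Phenylsulfonyl vinyl indoles: methoxy removal from the fused ring

A few compounds are considered here, and "the series" means these few. Any claim that something is new, unique, unknown or untested is made for them only; others in the source may bear on it.

Measured so far:
compound 1, `COc1ccc(-c2[nH]c3ccccc3c2/C=C(\C#N)S(=O)(=O)c2ccccc2)cc1`, 203 nM
compound 2, `CC(=O)/C(=C\c1c(-c2ccccc2)[nH]c2ccccc12)S(=O)(=O)c1ccccc1`, 295 nM
compound 3, `COc1ccc2[nH]c(-c3ccccc3)c(/C=C(\C#N)S(=O)(=O)c3ccccc3)c2c1`, 1100 nM

In a functional assay on MDA-MB-435 cells (Homo sapiens) for inhibition, read by sulforhodamine B assay, with a stated time of 48 h (a higher number here means a weaker inhibitor of growth, a lower number a stronger inhibitor of growth), compound 3 gives the highest of the three numbers. Its nearest neighbour is compound 2, which gives 295 nM, and furthest from it is compound 1, which gives 203 nM; both of these gaps lie beyond the scatter of repeated measurement. For the measured compounds named here, no pair of measured compounds differs in a single place, so no direct step can be read off for any one change.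

Compound 4, `N#C/C(=C\c1c(-c2ccccc2)[nH]c2ccccc12)S(=O)(=O)c1ccccc1`, is not yet measured. It differs from compound 3 by hydrogen in place of methoxy on an aromatic carbon; the change sits on an aromatic carbon of a six-membered aromatic ring of carbon only, part of the fused system of two rings. Compounds 1 and 2 both lack a methoxy on that fused ring and give lower numbers than compound 3, so a lower number for compound 4 in this assay is expected, a step of about a 3.4-fold lower number from compound 3 to compound 4 (0.54 log units; beyond the scatter), in size beyond the scatter. For compound 4 the estimate is 320 nM, with a range from 130 nM to 800 nM.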

Compound 4, concentration for 50% growth inhibition: 288 nM
Beside the measured number, compound 4's estimate is 1.1-fold (0.05 log units) above it; the measured number falls inside the stated range.
By their numbers in this assay, from the lowest: compounds 1, 4 and 2 (each within the scatter of the next); then compound 3.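

In this assay, for the compounds shown here, hydrogen in place of methoxy on the fused ring gives a 3.8-fold lower number from compound 3 to compound 4 (0.58 log units; beyond the scatter) and so provides the first direct reading at this position, showing that the methoxy there goes with a higher number. The same replacement at the methoxy of compound 1, a different place in the structure, gives a 1.4-fold higher number from compound 1 to compound 4 (0.15 log units; within the scatter) and stays within the scatter, while cyano in place of acetyl on the double-bonded chain carbon gives a 1.0-fold lower number from compound 2 to compound 4 (0.01 log units; within the scatter) and also stays within the scatter, so neither of these two changes separates the compounds in this read-out. No measurement on hand explains why the methoxy counts on the fused ring and not at the place it occupies in compound 1.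

Only methoxy and hydrogen are shown at this position, so it remains open how a hydroxyl, a chlorine, an amine or a carboxylic acid there would read, and whether another place on the fused ring responds in the same way. On these data alone, it is also open whether the methoxy carries the same step when acetyl replaces the cyano group, as the acetyl side has a single compound here.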